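A few compounds are considered here, and "the series" means these few. Any claim that something is new, unique, unknown or untested is made for them only; others in the source may bear on it.

Measured so far in a functional assay on MEL28 cells (Homo sapiens) for cytotoxicity; a lower number here means a stronger inhibitor, a higher number a weaker inhibitor:
compound 1 `C=CCC/C=C\C=C/CCCCCCCC[C@@H]1CC[C@@H]([C@@H]2CC[C@@H](CC(=O)OC)OO2)O1`: 0.1 ug/mL
compound 2 `C=CCC/C=C\C=C/CCCCCCCC[C@H]1CC[C@H]([C@@H]2CC[C@@H](CC(=O)OC)OO2)O1`: 0.5 ug/mL

Compound 2 stands at the higher number of the pair, at 0.5 ug/mL, which makes it the weaker inhibitor of the two. Among the compounds with values here, the only measured step is a 5.0-fold higher number from compound 1 to compound 2 (0.70 log units; beyond the scatter), and it goes with the fact that compounds 1 and 2 differ only in the configuration as drawn.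

Compound 3 `C=CCCC/C=C/C=C\CCCCCCCC[C@H]1CC[C@H]([C@@H]2CC[C@@H](CC(=O)OC)OO2)O1` has not yet been measured. Its difference from compound 2 is a group of 7 heavy atoms (7 carbon; no ring) in place of a group of 6 heavy atoms (6 carbon; no ring), on a double-bonded chain carbon bound to a double-bonded chain carbon: hepta-1,6-dien-1-yl enters on a double-bonded chain carbon bound to a double-bonded chain carbon. Within the data shown here, no measured step involves a change of this group, since a 5.0-fold higher number from compound 1 to compound 2 (0.70 log units; beyond the scatter) concerns configuration alone. That step therefore gives no direction for this change, and no shift beyond the scatter is expected in this assay, so compound 2 at 0.5 ug/mL remains the anchor. The expected outcome is no change at the digits printed from compound 2 to compound 3 (within the scatter). For compound 3 the estimated value is 0.5 ug/mL, with an expected range of 0.15 ug/mL to 1.5 ug/mL.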

Compound 3, half-maximal inhibitory concentration: 0.1 ug/mL
Compound 3: the middle estimate sits 5.0-fold (0.70 log units) above what was measured; measured number below the stated range.
By their numbers in this assay, from the lowest: compounds 1 and 3 (each within the scatter of the next); then compound 2.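

In this assay, the group on a double-bonded chain carbon bound to a double-bonded chain carbon turns out to matter: hepta-1,6-dien-1-yl in place of the six-carbon group gives a 5.0-fold lower number from compound 2 to compound 3 (0.70 log units; beyond the scatter). The earlier compounds shown here offered only a change of configuration, a 5.0-fold higher number from compound 1 to compound 2 (0.70 log units; beyond the scatter), so the series now has a second place where a single change moves the number beyond the scatter, and by the same size of step. No information given here bears on why this change of chain moves the number.

As far as these compounds go, whether hepta-1,6-dien-1-yl has the same effect in the configuration of compound 1 remains open, since a single step cannot show whether the two changes add. Also open, from the compounds shown here alone, is how a longer chain, or a chain ending in an amine or a carboxylic acid, would behave at this place.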